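The compounds below may be only part of what the source reports. "The series", "measured", "known", "first", "only" and "open" are said of these compounds alone.

Measured so far:
- compound 1, `CCCCCC[C@@H](O)C/C=C\CCCCCCCC(=O)N[C@@H](C)c1ccccc1`: 1.9 ug/mL
- compound 2, `CCCCCCCCCCCCCCCCCC(=O)N1CCOCC1`: 33.1 ug/mL
- compound 3, `CCCCC/C=C\C/C=C\CCCCCCCC(=O)N1CCCCC1`: 63.2 ug/mL

The read-out for all three is a functional assay on NCI/ADR-RES cells (Homo sapiens) for antiproliferative activity, read by sulforhodamine B assay, with a stated time of 48 h; on this read-out higher numbers stand for weaker inhibition of growth and lower numbers for stronger inhibition of growth. Compound 1 gives 1.9 ug/mL and stands apart from the other two by a gap beyond the scatter. Compound 2, with 33.1 ug/mL, holds the second highest of the three numbers; its nearest neighbour is compound 3 at 63.2 ug/mL, and the two values lie within the scatter of each other, so no order between them is claimed. Compound 1 sits well below compound 2.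

The next compound, compound 4 with structure `CCCCCCCCCCCCCCCCCC(=O)N1CCCC1`, is not yet measured. It differs from compound 2 in one place: pyrrolidin-1-yl in place of morpholin-4-yl on a carbonyl carbon. For the measured compounds named here, no measured pair in the set carries this change, so nothing here shows its effect directly. Both the leaving and the entering group are small saturated rings on the same carbonyl carbon at the end of the same chain, and compound 2 and compound 3, which carry different amide rings, show values within the scatter of each other. The step is therefore expected to be small, with no clear direction beyond the scatter, and the expected step of a 1.1-fold lower number from compound 2 to compound 4 (0.04 log units; within the scatter) reflects this. For compound 4 the expected value in this assay is 30 ug/mL, with a range from 12 ug/mL to 80 ug/mL.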

Compound 4, concentration for 50% growth inhibition: 7.1 ug/mL
The estimate for compound 4 lay 4.2-fold (0.63 log units) above the measured number; measured number outside the range, below it.
By their numbers in this assay, from the lowest: compound 1; then compound 4; then compounds 2 and 3 (each within the scatter of the next).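

With the saturated chain held fixed, the ring on the carbonyl carbon affects the read-out in this assay: pyrrolidin-1-yl in place of morpholin-4-yl gives a 4.7-fold lower number from compound 2 to compound 4 (0.67 log units; beyond the scatter). For the compounds shown here, this is the first pair that differs in one place, and it shows that a modest change in the amide ring alone can move the number beyond the scatter. Nothing measured here accounts for the step.

The change replaces a six-membered ring with two hetero atoms by a five-membered ring with one, and this single pair cannot show whether ring size or the ring oxygen matters. It also leaves open how an azetidin-1-yl ring or an open-chain diethylamino group on the same carbonyl carbon would read.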